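Bromo in place of methoxy: expectation for compound 4

The compounds below may be only part of what the source reports. "The series", "measured", "known", "first", "only" and "open" are said of these compounds alone.

Compound 2 `COc1ccc(C2=NO[C@@H]3[C@H](CO)C[C@H](CO)[C@H]23)cc1` gives 23.7 ug/mL in a functional assay on MCF7 cells (Homo sapiens) for cytotoxicity, read by MTT assay, with a stated time of 48 h; on this read-out higher numbers stand for weaker inhibition and lower numbers for stronger inhibition. Among the two numbers shown it stands highest; the nearest neighbour, compound 3 `OC[C@@H]1C[C@H](CO)[C@@H]2C(c3ccc4ccccc4c3)=NO[C@H]12`, gives 11.5 ug/mL in this assay, and the gap between the two lies beyond the scatter. Compound 1 `COc1ccc(C2=NO[C@@H]3[C@H](CO)C[C@H](CO)[C@H]23)cc1OC` reaches only a limit of the assay, > 50 ug/mL in this assay, and so supplies no number (the limit of > 50 ug/mL in this assay, at which 1 of the 3 values shown sits).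

Among the compounds with values here, the single measured step within the set, an at least 2.1-fold lower number from compound 1 to compound 2 (0.32 log units; beyond the scatter), is the removal of a methoxy from an aromatic carbon; the number fell by a margin beyond the scatter, though only a lower bound on its size is known.

Compound 4 `OC[C@@H]1C[C@H](CO)[C@@H]2C(c3ccc(Br)cc3)=NO[C@H]12` differs from compound 2 in one place: bromo in place of methoxy on an aromatic carbon. The measured step bears on this only in part, since it too takes away a methoxy, but hydrogen rather than bromo took its place. Within the data shown here, with no bromo analogue measured in the set, the expectation leans on that one step and on compound 3 sitting below compound 2 in the same assay.

A modest lowering of the number is therefore expected, a 1.6-fold lower number from compound 2 to compound 4 (0.20 log units; within the scatter), not far beyond the scatter. Compound 4 is estimated to give 15 ug/mL in this assay, within a likely range from 6 ug/mL to 35 ug/mL.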

Compound 4, half-maximal inhibitory concentration: > 50 ug/mL
Compound 4 was reported as a limit; the forecaster's own chance of this, stated with the estimate: 5%; middle value at least 3.3-fold (0.52 log units) away from the limit.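

In this assay, bromo in place of methoxy para to a large group moves the number the opposite way from the earlier step that took a methoxy away: an at least 2.1-fold higher number from compound 2 to compound 4 (0.32 log units; beyond the scatter) here, against an at least 2.1-fold lower number from compound 1 to compound 2 (0.32 log units; beyond the scatter) there. Losing a methoxy from the aromatic ring therefore does not lower the number in itself, and the earlier step does not carry over to this position and this change. Compound 4 gives a limit and not a number, so only a lower bound on the size of the rise is known: the limit of > 50 ug/mL in this assay, at which 2 of the 4 values shown sit.

As far as these compounds go, how hydrogen, chloro, hydroxy or an amine at this position would read against compound 2 remains open, so it is not settled whether the rise belongs to bromo in particular or to any loss of this methoxy. With the value of compound 4 resting at a limit, how far compound 4 really lies from compound 2 also stays unresolved.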